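The compounds below may be only part of what the source reports. "The series", "measured", "known", "first", "only" and "open" are said of these compounds alone.

Compound 1 `CCC(C)(C)Cc1c[nH]c(CCc2ccc(-c3ccncc3)cc2)n1`: 103 nM
Compound 2 `CCC(C)(C)Cc1c[nH]c(CCc2ccc(-n3ccnn3)cc2)n1`: 111 nM

In a functional assay on HEK293 cells for agonist activity at Bombesin receptor subtype-3 (Mus musculus), read by luminescence and calcium flux, with a stated time of 10 min (a higher number here means that more compound is needed for the effect, a lower number that less compound is needed), compound 1 stands at one end of a pair whose only step, a 1.1-fold higher number from compound 1 to compound 2 (0.03 log units; within the scatter), lies within the scatter, so the two values cannot be told apart. Compound 3 `CCC(C)(C)Cc1c[nH]c(CCc2ccc(-c3ccc(F)cn3)cc2)n1` differs from compound 1 as follows: 5-fluoropyridin-2-yl in place of pyridin-4-yl on an aromatic carbon. For the measured compounds named here, the one measured step exchanged the same departing group for a different ring and produced no change beyond the scatter; that step bears on the present change only loosely. For compound 3 the expected step is a 1.0-fold lower number from compound 1 to compound 3 (0.01 log units; within the scatter), so compound 3 is estimated at 100 nM, within the range 50 nM to 200 nM.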

Compound 3, half-maximal effective concentration: 105 nM
Compound 3: the middle estimate sits 1.1-fold (0.02 log units) below what was measured; the measured number falls inside the stated range.
By their numbers in this assay, from the lowest: compounds 1, 3 and 2 (each within the scatter of the next).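

Placing 5-fluoropyridin-2-yl on this aromatic carbon, para to a large group, gives a third ring that cannot be told apart from the other two in this assay (a 1.0-fold higher number from compound 1 to compound 3 (0.01 log units; within the scatter); a 1.1-fold lower number from compound 2 to compound 3 (0.02 log units; within the scatter)). The fluorine-bearing ring therefore adds a second pyridine-type case and shows that a fluorine on it comes with no step beyond the scatter. Nothing shown explains this result. Whether an amine, a carboxylic acid or a longer chain would be accepted here remains open, since all three groups shown are aromatic rings.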